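Inverting all three stereocentres of compound 1 in intestinal fluid

The source may hold more compounds than are shown below. What is called first, only, known or untested is meant among the compounds shown, and "the series" means these compounds.

Compound 1 `O=C(O)[C@H](CO)NC(=O)[C@@H]1C[C@@H](O)CN1` is the reference of this pair. In an ADME assay for metabolic stability, read by HPLC, in simulated intestinal fluid, with a stated time of 12 h, at pH 6.8 (a higher number here means that the compound lasts longer, a lower number that the compound disappears faster), compound 1 gives > 12 h, which is a limit of the assay and not a number. Compound 2 `O=C(O)[C@H](CO)NC(=O)[C@H]1C[C@@H](O)CN1` differs from compound 1 in one stereocentre at a saturated ring carbon. In this assay compound 2 gives > 12 h, again a limit rather than a number. The step that the two limits leave unreadable from compound 1 to compound 2 therefore cannot be sized because of the limit of > 12 h in this assay, at which 2 of the 2 values shown sit.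

Compound 3 `O=C(O)[C@@H](CO)NC(=O)[C@H]1C[C@H](O)CN1` is the mirror image of compound 1: the two compounds have the same atoms and bonds and differ only in configuration as drawn: 3 of 3 stereo elements differ (all stereocentres are inverted: mirror images); a stereocentre at a saturated chain carbon is drawn S in compound 1 and R in compound 3; a stereocentre at a saturated ring carbon is drawn S in compound 1 and R in compound 3; a stereocentre at a saturated ring carbon is drawn R in compound 1 and S in compound 3. Within the data shown here, the only measured step that bears on a change of configuration is the one from compound 1 to compound 2, and its size is not readable. With both known values sitting at the limit, no step beyond the scatter is expected, so compound 3 is estimated at a step that the limit leaves unreadable from compound 1 to compound 3. Compound 3 is thus expected to give 20 h, in a range from 12 h to 40 h, most likely reported again as a limit.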

Compound 3, half-life: > 12 h
Compound 3: a limit, no number (the forecaster's own chance of this, stated with the estimate: 80%); the middle value does not contradict the limit.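

In this assay compound 3 gives > 12 h, a limit and not a number. Among these compounds, no step between compound 1, compound 2 and compound 3 can be read: the limit of > 12 h in this assay, at which 3 of the 3 values shown sit. The compounds shown leave open whether configuration changes the half-life in this assay at all.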